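Shifting the Thiophene Link in a Two-Phenol Series

The source may hold more compounds than are shown below. What is called first, only, known or untested is meant among the compounds shown, and "the series" means these compounds.

Among the measured compounds shown here, in a functional assay on HeLa cells (Homo sapiens) for cytotoxicity, read by CCK-8 assay (a higher number here means a weaker inhibitor, a lower number a stronger inhibitor), compound 2 `Oc1cccc(-c2cc(-c3cccs3)cc(-c3cccc(O)c3)n2)c1` gives 1690 nM, the only number reported here. Compound 1 `Oc1cccc(-c2cc(-c3cccs3)cc(-c3ccccc3O)n2)c1` sits at a limit of the assay, > 50000 nM. For the measured compounds named here, the one measured step, an at least 29-fold lower number from compound 1 to compound 2 (1.47 log units; beyond the scatter), concerns the hydroxyphenyl groups and not the thiophene. Compound 3 `Oc1cccc(-c2cc(-c3ccsc3)cc(-c3cccc(O)c3)n2)c1` differs from compound 2 by thiophen-3-yl in place of thiophen-2-yl on an aromatic carbon, so that measured step gives no direct guide. Going by the values given here, with no measured step at this site, the expected change a 1.0-fold higher number from compound 2 to compound 3 (0.00 log units; within the scatter) is none beyond the scatter. The estimate for compound 3 is 1700 nM, between 500 nM and 6000 nM.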

Compound 3, half-maximal inhibitory concentration: 16600 nM
The estimate for compound 3 lay 9.8-fold (0.99 log units) below the measured number; measured number outside the range, above it.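

In this assay, merely changing the thiophene's point of attachment, with the same atoms in the group, gives a 9.8-fold higher number from compound 2 to compound 3 (0.99 log units; beyond the scatter). The earlier step showed sensitivity only at the hydroxyphenyl groups; this one shows that the position opposite the ring nitrogen also responds, even to a change of attachment alone. Nothing measured here accounts for this difference.

Still open, as far as these compounds go, is how a furan ring or an amine at this position would compare with the thiophenes. From the compounds shown here alone, it is also open whether the same gap between the two thiophenes would appear with other hydroxyphenyl arrangements.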